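The compounds below may be only part of what the source reports. "The series", "measured", "known", "first", "only" and "open" are said of these compounds alone.

Measured so far in an assay for inhibition of Intestinal-type alkaline phosphatase (Homo sapiens), read by spectrophotometry, with stated times of 10 min and 20 min; on this read-out higher numbers stand for weaker inhibition and lower numbers for stronger inhibition:
compound 1 `COc1cccc(/C=C2\NS(=O)(=O)c3ccccc3C2=O)c1` — 1040 nM
compound 2 `COc1ccc(/C=C2\NS(=O)(=O)c3ccccc3C2=O)cc1` — 1530 nM

Compound 1 gives the lowest of the two numbers in this assay; compound 2 sits within the scatter of it, so the two show no separation. Compound 3 `O=C1/C(=C/c2cccc(Cl)c2)NS(=O)(=O)c2ccccc21` differs from compound 1 by chloro in place of methoxy on an aromatic carbon. For the measured compounds named here, no measured pair shows this change here, so nothing fixes its size; a step within the scatter in either direction is expected. Compound 3 is accordingly estimated at 900 nM in this assay, between 350 nM and 2500 nM, a step of a 1.2-fold lower number from compound 1 to compound 3 (0.06 log units; within the scatter).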

Compound 3, half-maximal inhibitory concentration: 3770 nM
Estimate against measurement, compound 3: 4.2-fold (0.62 log units) below, outside the stated range (above it).
By their numbers in this assay, from the lowest: compounds 1 and 2 (each within the scatter of the next); then compound 3.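

In this assay chloro in place of methoxy on this aromatic carbon, meta to a large group, gives a 3.6-fold higher number from compound 1 to compound 3 (0.56 log units; beyond the scatter) and is the only step shown that lies beyond the scatter, though a modest one. This position therefore does respond to a change of substituent, and methoxy reads better here than chloro. No evidence on hand accounts for the step.

The compounds shown leave open whether the higher number follows from losing methoxy or from bringing in chloro. Going by these compounds, how an amine or a carboxylic acid on this carbon would read also remains open.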